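A few compounds are considered here, and "the series" means these few. Any claim that something is new, unique, unknown or untested is made for them only; others in the source may bear on it.

Compound 1 `CC(C)(C)c1ccc(C(=O)NCc2ccc(NS(C)(=O)=O)cc2)cc1`, which in an assay on HeLa cells with Bile acid receptor (Homo sapiens) as the target, read by a luciferase reporter, with a stated time of 24 h (on this read-out lower numbers stand for an effect already at smaller amounts and higher numbers for an effect only at larger amounts of compound), gives 44 nM
Compound 2 `CC(C)(C)c1ccc(C(=O)NCc2ccc(-c3nnn[nH]3)cc2)cc1`, which in this assay gives 120 nM
Compound 3 `CC(C)(C)c1ccc(C(=O)NCc2ccc(OC(F)(F)F)cc2)cc1`, which in this assay gives 160 nM

All three share one core and differ only in the group on the outer aromatic ring. Compound 3 stands at the high end of these numbers: a 3.6-fold higher number from compound 1 to compound 3 (0.56 log units; beyond the scatter) lies beyond the scatter, whereas a 1.3-fold higher number from compound 2 to compound 3 (0.12 log units; within the scatter) lies within it, so compound 3 and compound 2 cannot be told apart on these data.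

Compound 4 `CC(C)(C)c1ccc(C(=O)NCc2ccc(S(C)(=O)=O)cc2)cc1` has not yet been measured. It differs from compound 3 by methylsulfonyl in place of trifluoromethoxy on an aromatic carbon. Among the compounds with values here, no measured step swaps exactly these two groups, so the guide is indirect. Compound 1 also carries a sulfonyl-containing group, and a 3.6-fold higher number from compound 1 to compound 3 (0.56 log units; beyond the scatter) shows that exchanging it for trifluoromethoxy raised the number; a 2.7-fold higher number from compound 1 to compound 2 (0.44 log units; beyond the scatter) points the same way for tetrazolyl. A lower number is therefore expected for compound 4, a step of about a 2.0-fold lower number from compound 3 to compound 4 (0.30 log units; within the scatter), smaller than the gap to compound 1. Compound 4 is estimated at 80 nM in this assay, within a range from 30 nM to 250 nM.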

Compound 4, half-maximal effective concentration: 3800 nM
For compound 4 the middle estimate is 48-fold (1.68 log units) below the measured one; the whole stated range lies below it.
By their numbers in this assay, from the lowest: compound 1; then compounds 2 and 3 (each within the scatter of the next); then compound 4.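

Methylsulfonyl on this aromatic carbon, para to a large group, brings the first large change in the series: a 24-fold higher number from compound 3 to compound 4 (1.38 log units; beyond the scatter), and a 32-fold higher number from compound 2 to compound 4 (1.50 log units; beyond the scatter), whereas the steps among the earlier compounds were modest or within the scatter. The sulfonyl unit alone therefore does not secure a low number in this assay: methanesulfonamido and methylsulfonyl both contain it, yet there is an 86-fold higher number from compound 1 to compound 4 (1.94 log units; beyond the scatter), the widest gap in the set. Nothing measured here explains why this exchange has so large an effect.

The compounds shown leave open whether a carboxylic acid, an amine or a primary sulfonamide on this aromatic carbon would give a number near that of compound 1 or that of compound 4. They also leave open whether replacing methanesulfonamido with methylsulfonyl would produce a step of similar size on a different core.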